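The source may report more compounds than this note shows. Statements on the series, on what has been measured and on what is new or still open speak of the compounds shown alone.

Measured in a functional assay on the whole organism for inhibition, with Scenedesmus acutus as the target; a higher number here means a weaker inhibitor, a lower number a stronger inhibitor:
- compound 1 `CC(C)OC(=O)c1cc(N2C(=O)C3=C(CCCC3)C2=O)ccc1Cl`: 1230 nM
- compound 2 `CC(C)COC(=O)c1cc(N2C(=O)C3=C(CCCC3)C2=O)ccc1Cl`: 977 nM
- compound 3 `CC(C)(C)OC(=O)c1cc(N2C(=O)C3=C(CCCC3)C2=O)ccc1Cl`: 81300 nM

Compound 3 has the highest number of the three, while the other two lie within the scatter of each other, with a 1.3-fold lower number from compound 1 to compound 2 (0.10 log units; within the scatter). Compound 4 `C#CCOc1cc(N2C(=O)C3=C(CCCC3)C2=O)ccc1Cl` differs from compound 3 by one change: propargyloxy in place of tert-butoxycarbonyl on an aromatic carbon. The measured steps that bear on it are a 66-fold higher number from compound 1 to compound 3 (1.82 log units; beyond the scatter) and an 83-fold higher number from compound 2 to compound 3 (1.92 log units; beyond the scatter), both large and both set compound 3 apart from the other two esters. For the measured compounds named here, no measured compound carries propargyloxy, so the expectation is uncertain. A large fall toward the level of those two esters is expected, an estimated 100-fold lower number from compound 3 to compound 4 (2.01 log units; beyond the scatter). For compound 4 the estimated value is 800 nM, with an expected range of 100 nM to 6000 nM.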

Compound 4, half-maximal inhibitory concentration: 100 nM
Compound 4: middle estimate off by 8.0-fold (0.90 log units), on the high side, and the stated range covers the measured number.
By their numbers in this assay, from the lowest: compound 4; then compounds 2 and 1 (each within the scatter of the next); then compound 3.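

At this aromatic carbon, ortho to the chloro group, an ester is not needed for inhibition in this assay: propargyloxy gives a 12-fold lower number from compound 1 to compound 4 (1.09 log units; beyond the scatter) and a 9.8-fold lower number from compound 2 to compound 4 (0.99 log units; beyond the scatter), as well as an 810-fold lower number from compound 3 to compound 4 (2.91 log units; beyond the scatter). The earlier compounds shown here changed only the alkyl part of the ester, whereas this change removes the carbonyl and gives the strongest inhibitor of the four. Nothing measured here explains these steps. The compounds shown leave open whether the gain follows the ether oxygen or the triple bond, which a propoxy or allyloxy group on this carbon would separate.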